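The source may report more compounds than this note shows. Statements on the series, on what has been measured and on what is new or still open speak of the compounds shown alone.

In a functional assay on KB cells (Homo sapiens) for antiproliferative activity, read by sulforhodamine B assay, with a stated time of 48 h (a higher number here means a weaker inhibitor of growth, a lower number a stronger inhibitor of growth), three compounds that share a core and differ in one aromatic substituent have been measured. Compound 1 `COc1ccc(Nc2nc(NC3CCCC3)c3ccccc3n2)cc1`, with methoxy, gives 11100 nM. Compound 2 `N#Cc1ccc(Nc2nc(NC3CCCC3)c3ccccc3n2)cc1`, with cyano, gives > 31300 nM, which is a limit of the assay and not a number. Compound 3 `Nc1ccc(Nc2nc(NC3CCCC3)c3ccccc3n2)cc1`, with amino, gives 17400 nM. This places compound 3 within the scatter of compound 1, with a 1.6-fold higher number from compound 1 to compound 3 (0.20 log units; within the scatter). The other two steps are an at least 2.8-fold higher number from compound 1 to compound 2 (0.45 log units; beyond the scatter) and an at least 1.7-fold lower number from compound 2 to compound 3 (0.25 log units; that floor lies within the scatter).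

Compound 4 `Nc1ccc(Nc2nc(NCCCO)c3ccccc3n2)cc1` keeps the amino substituent and changes the other side of the core: 3-hydroxypropyl in place of cyclopentyl on a nitrogen on an aromatic ring. In words, 3-hydroxypropyl stands in place of cyclopentyl on a nitrogen on an aromatic ring. For the measured compounds named here, none of the measured steps touches this place, since all three exchange the aromatic substituent, so they bear on it only indirectly. They offer a rough scale, and the only step shown as beyond the scatter is the modest one to compound 2. A modest move to a higher number is therefore expected, although no step beyond the scatter remains possible. The estimated change is a 1.4-fold higher number from compound 3 to compound 4 (0.16 log units; within the scatter). For compound 4, the expected value is 25000 nM, with an estimated range from 10000 nM to 60000 nM.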

Compound 4, concentration for 50% growth inhibition: 19700 nM
The estimate for compound 4 lay 1.3-fold (0.10 log units) above the measured number, within the range that was stated.
By their numbers in this assay, from the lowest: compounds 1, 3 and 4 (each within the scatter of the next). At a limit, above all of these: compound 2.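

In this assay, for the compounds shown here, the only step at the nitrogen on an aromatic ring is a 1.1-fold higher number from compound 3 to compound 4 (0.05 log units; within the scatter), so in this pair 3-hydroxypropyl and cyclopentyl cannot be told apart. The earlier steps shown here all exchanged the aromatic substituent, whereas this one removes the five-membered ring of carbon and brings in an open chain with an oxygen, and the number still stays within the scatter with the amino substituent held fixed. Nothing measured here offers a reason for this result.

Going by these compounds alone, compound 3 and compound 4 are the only pair that differs at this place, so it remains open whether the same exchange would leave the number within the scatter with methoxy or cyano on the aromatic carbon. Also open, as far as these compounds go, is what a cyclohexyl group, a longer chain, or a chain ending in an amine or a carboxylic acid would give on this nitrogen in this assay.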